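The compounds below may be only part of what the source reports. "The series", "measured", "known", "first", "only" and "open" are said of these compounds alone.

Values in an ADME assay on HepG2 cells (Homo sapiens) for cytotoxicity, read by CellTiter-Glo and resazurin assay, with a stated time of 72 h (a lower number here means that less compound is needed, a higher number that more compound is needed for the effect), each of them a limit of the assay rather than a number:
compound 1 `CCCN(Cc1ccc(OCCCCCC(=O)OCC)cc1)C(=O)c1ccc(Br)cc1`: > 26000 nM
compound 2 `CCOC(=O)CCCCCOc1ccc(CNC(C)C)cc1`: > 26000 nM
compound 3 `CCCNCc1ccc(OCCCCCC(=O)OCC)cc1`: > 26000 nM

Compound 3 stands at the limit of this assay. All three values sit at the limit of > 26000 nM in this assay, at which 3 of the 3 values shown sit, so no order among the three compounds can be read. The step from compound 1 to compound 3 is a step that the two limits leave unreadable from compound 1 to compound 3. The step from compound 2 to compound 3 is a step that the two limits leave unreadable from compound 2 to compound 3. Neither gives a size that could be carried forward.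

Compound 4 `CCOC(=O)CCCCCOc1ccc(C=O)cc1` differs from compound 3 by formyl in place of (propylamino)methyl on an aromatic carbon. Within the data shown here, no measured step touches this change; both recorded steps are unreadable, so there is no size to transfer. The expectation in this assay therefore rests on where compound 3 stands, at its limit. The step is expected to be a number no higher from compound 3 to compound 4 (the limit leaves the size open), that is, none beyond the scatter. Compound 4 is estimated at 26000 nM, within 10000 nM to 60000 nM, and most likely reported again as a limit.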

Compound 4, half-maximal effective concentration: > 26000 nM
Compound 4 was reported as a limit; the forecaster's own chance of this, stated with the estimate: 70%; the middle value sits exactly at the limit.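

Compound 4 gives no readable step from compound 3 or compound 2 in this assay, as its value is again a limit: the limit of > 26000 nM in this assay, at which 4 of the 4 values shown sit.

The compounds shown leave open how far each lies from that limit, and whether any change on the shared core alters the value in this assay.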